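Losing the sulfur-bearing group of compound 2

The compounds below may be only part of what the source reports. "The series", "measured", "known", "first", "only" and "open" are said of these compounds alone.

In a functional assay on SMMC-7721 cells (Homo sapiens) for antiproliferative activity, read by MTT assay, with a stated time of 48 h (on this read-out higher numbers stand for weaker inhibition and lower numbers for stronger inhibition), compound 1 `COC/C1=C/C[C@](C)(CCC=C(C)C)/C=C/[C@@H](OC(=O)C=C(C)C)[C@](C)(O)/C=C/C1=O` gives 11000 nM while compound 2 `CSC(=S)OC/C1=C/C[C@](C)(CCC=C(C)C)/C=C/[C@@H](OC(=O)C=C(C)C)[C@](C)(O)/C=C/C1=O` gives 720 nM and so holds the lower of the two numbers. Going by the values given here, the single measured step is a 15-fold lower number from compound 1 to compound 2 (1.18 log units; beyond the scatter) and it brings in the sulfur-bearing group. Compound 3 `CC(C)=CCC[C@]1(C)/C=C/[C@@H](OC(=O)C=C(C)C)[C@](C)(O)/C=C/C(=O)/C(C(=O)N(C(C)C)C(C)C)=C\C1` differs from compound 2 by a group of 9 heavy atoms (7 carbon, 1 nitrogen, 1 oxygen; no ring) in place of a group of 6 heavy atoms (3 carbon, 1 oxygen, 2 sulfur; no ring), on a double-bonded ring carbon and so loses that group. Among the compounds with values here, no measured compound carries diisopropylcarbamoyl, which makes that step only a partial guide. In this assay the expected change is a 6.9-fold higher number from compound 2 to compound 3 (0.84 log units; beyond the scatter) toward a higher number, smaller in size than the measured step. Compound 3 is estimated at 5000 nM with a range from 1500 nM to 20000 nM in this measurement.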

Compound 3, half-maximal inhibitory concentration: 17200 nM
Compound 3: the middle estimate sits 3.4-fold (0.54 log units) below what was measured; low and high end bracket the measured number.
By their numbers in this assay, from the lowest: compound 2; then compounds 1 and 3 (each within the scatter of the next).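

In this assay the diisopropylcarbamoyl group on the double-bonded ring carbon gives a 24-fold higher number from compound 2 to compound 3 (1.38 log units; beyond the scatter) and so does not keep what the sulfur-bearing group brought. Against methoxymethyl on that same carbon it gives a 1.6-fold higher number from compound 1 to compound 3 (0.19 log units; within the scatter) and thus no separation, so of the three groups at this place only the sulfur-bearing one stands apart. Nothing at hand explains why the sulfur-bearing group differs from the other two. The compounds shown leave open whether a thioether or a dithiocarbamate at this carbon would match compound 2. They also leave open how a carboxylic acid or an amine there would compare.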